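The source may hold more compounds than are shown below. What is called first, only, known or untested is meant among the compounds shown, and "the series" means these compounds.

Measured compounds:
compound 1 `O=C(CSc1nc2ccccc2s1)N/N=C/c1ccc(Oc2ccccc2)cc1` with 5.6
compound 2 `Cc1cc(Oc2ccc(/C=N/NC(=O)CSc3nc4ccccc4s3)cc2)ccc1Cl` with 5.7
compound 3 `O=C(CSc1nc2ccccc2s1)N/N=C/c1ccc(Oc2ccc3ccccc3c2)cc1` with 5.9

In a physicochemical assay for lipophilicity, in phosphate buffer, measured as octanol-water partition, with a stated time of 24 h (on this read-out lower numbers stand for lower lipophilicity and higher numbers for higher lipophilicity), compound 3 has the highest of the three numbers, though the steps of a number 0.30 log units higher from compound 1 to compound 3 (within the scatter) and a number 0.20 log units higher from compound 2 to compound 3 (within the scatter) are both within the scatter, so the three compounds are not separated. Compound 4 `O=C(CSc1nc2ccccc2s1)N/N=C/c1ccc(Oc2ccc(F)cc2)cc1` differs from compound 3 by 4-fluorophenyl in place of naphthalen-2-yl on an oxygen on an aromatic ring. Among the measured compounds shown here, the steps that bear on this are the ones at the same oxygen: a number 0.30 log units higher from compound 1 to compound 3 (within the scatter) and a number 0.20 log units higher from compound 2 to compound 3 (within the scatter), both small. Compound 4 undoes the naphthalen-2-yl gain of compound 3 and carries a fluorine that compound 1 lacks, so for compound 4 the expected step in this assay is estimated as a number 0.20 log units lower from compound 3 to compound 4 (within the scatter). Compound 4 is estimated at 5.7, between 5.4 and 6.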

Compound 4, partition coefficient: 5.5
For compound 4 the middle estimate is 0.20 log units above the measured one; low and high end bracket the measured number.
By their numbers in this assay, from the lowest: compounds 4, 1, 2 and 3 (each within the scatter of the next, the first and the last beyond it).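

In this assay, among the compounds shown here, a change on this oxygen gives a number 0.40 log units lower from compound 3 to compound 4 (beyond the scatter) as the first step to pass the scatter, though it is only modest. By contrast, a number 0.20 log units lower from compound 2 to compound 4 (within the scatter) and a number 0.10 log units lower from compound 1 to compound 4 (within the scatter) leave compound 4 unseparated from those two, so fluoro in place of hydrogen on an aromatic carbon gives no readable change. Nothing available explains why naphthalen-2-yl and 4-fluorophenyl differ here.

All four compounds carry only aromatic carbon rings on this oxygen. Going by these compounds, how the number would respond to a phenyl bearing a carboxylic acid, or to an amine chain there, remains open.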